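Compound 3 to compound 4: isobutylamino to diethylamino

This account rests on a few compounds, and the source may have more. Where it says the series, first, only, none or still open, it means among the compounds named here.

Measured in a functional assay on A2780 cells (Homo sapiens) for antiproliferative activity, read by MTT assay, with a stated time of 72 h; on this read-out higher numbers stand for weaker inhibition and lower numbers for stronger inhibition:
- compound 1 `N=C(NC(=N)NC1CCCC1)Nc1ccc(C(F)(F)F)cc1`: 2500 nM
- compound 2 `CC(C)CNC(=N)NC(=N)Nc1ccc(C(F)(F)F)cc1`: 2100 nM
- compound 3 `CC(C)CNC(=N)NC(=N)Nc1ccc(F)c(F)c1`: 6700 nM

Compound 3 carries the highest number of the three, and its distance from both compound 1 and compound 2 lies beyond the scatter. Compound 4 `CCN(CC)C(=N)NC(=N)Nc1ccc(F)c(F)c1` has the same atoms as compound 3, joined differently, with diethylamino in place of isobutylamino on a carbon with a double bond to nitrogen.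

Going by the values given here, only one measured step bears on this change. It is a 1.2-fold lower number from compound 1 to compound 2 (0.08 log units; within the scatter), with isobutyl in place of cyclopentyl on an amine nitrogen, and it stays within the scatter. Among the compounds with values here, that step swaps one carbon group for another but leaves the hydrogen-bond donor count unchanged, so no measured step covers the difference in donors between compound 3 and compound 4. Within the data shown here, the evidence therefore supports only a weak expectation: no step clearly beyond the scatter in this assay, with a slight lean towards a higher number.

The expected change is a 1.2-fold higher number from compound 3 to compound 4 (0.08 log units; within the scatter) at the centre of the estimate. Compound 4 is estimated at 8000 nM, with an expected range from 3000 nM to 20000 nM, kept wide for the untested donor difference.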

Compound 4, half-maximal inhibitory concentration: 20400 nM
Compound 4: middle estimate off by 2.6-fold (0.41 log units), on the low side; the measured number lies above the stated range.
By their numbers in this assay, from the lowest: compounds 2 and 1 (each within the scatter of the next); then compound 3; then compound 4.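

In this assay, going by these compounds alone, the exchange of isobutylamino for diethylamino on the carbon with a double bond to nitrogen gives a 3.0-fold higher number from compound 3 to compound 4 (0.48 log units; beyond the scatter) and is the first single-place change to go beyond the scatter. The earlier step, a 1.2-fold lower number from compound 1 to compound 2 (0.08 log units; within the scatter), swapped one carbon group for another on an amine nitrogen and stayed within the scatter; the new step shows that this place can register a change even between two groups made of the same atoms, where the count falls from 1 hydrogen-bond donor in isobutylamino to 0 in diethylamino. No measurement shown here explains the rise, so the link between that count and the higher number remains a coincidence of one pair, with nothing to support a cause.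

Ethylamino or a longer chain such as n-hexylamino at this place would be needed to tell whether the number follows the donor count or the shape of the carbon groups. Going by these compounds, it also remains open whether the same exchange gives a step of similar size on the core of compound 2, which carries trifluoromethyl.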